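The source may report more compounds than this note shows. Statements on the series, on what has been measured and on what is new or still open speak of the compounds shown alone.

Of the compounds shown here, three have so far been measured in a functional assay on PC-3 cells (Homo sapiens) for antiproliferative activity, read by MTT assay, with a stated time of 72 h; on this read-out lower numbers stand for stronger inhibition and higher numbers for weaker inhibition.

Compound 1 `O=C(COc1ccc(C(=O)/C=C/c2cccc(Cl)c2)cc1)N[C@H]1CCOC1=O` gives 4990 nM.
Compound 2 `CCCCCCCCCCSC(=S)N[C@H]1CCOC1=O` gives > 64000 nM, which is a limit of the assay rather than a number.
Compound 3 `O=C(CNc1ccccc1F)N[C@H]1CCOC1=O` gives > 64000 nM, again a limit and not a number.

Among these, compound 1 is the only compound with an actual number in this assay; the other two sit at the limit of > 64000 nM in this assay, at which 2 of the 3 values shown sit, so no measured step between any two of them can be worked out, and nothing says how far apart the three really are.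

The compound now in question, compound 4 `O=C(COc1ccc(C(=O)/C=C/c2cccc(Br)c2)cc1)N[C@H]1CCOC1=O`, differs from compound 1 in a single place: bromo in place of chloro on an aromatic carbon. In words, it is bromo in place of chloro on an aromatic carbon, meta to a large group, on a six-membered aromatic ring of carbon only; one bond further out, the change reads 3-chlorophenyl to 3-bromophenyl.

Among the measured compounds shown here, because no step between measured compounds is available, the expectation rests on the change itself and on compound 1 alone. A swap of one halogen for the next on an aromatic ring is expected to move the read-out by no more than the usual scatter, so the expected step from compound 1 to compound 4 is a 1.1-fold lower number from compound 1 to compound 4 (0.04 log units; within the scatter), in no definite direction. On that basis compound 4 is estimated at 4500 nM, with a likely range from 2000 nM to 10000 nM.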

Compound 4, half-maximal inhibitory concentration: 7890 nM
The estimate for compound 4 lay 1.8-fold (0.24 log units) below the measured number; the range from low to high includes it.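

Among the compounds shown here, the swap of chloro for bromo gives the first step that can be read in this assay, and at a 1.6-fold higher number from compound 1 to compound 4 (0.20 log units; within the scatter) it shows that this read-out does not tell the two halogens apart at this place on the ring. Until now, compound 1 stood alone with a number, so nothing showed whether its activity would survive any change at all; compound 4 shows that it survives this one, since compound 4 also gives a real number and not a limit of the assay. This is one exchange of one halogen for another at a single place, on a single cell line, and the compounds shown offer no measured property that would explain the outcome.

From the compounds shown here alone, whether this place tolerates only halogens stays open, since an amine, a carboxylic acid or a longer chain there might move the number well beyond the usual scatter. It is equally open whether the 3-chlorophenyl group needs a substituent at all, since the plain phenyl analogue of compound 1 is not among the compounds shown.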